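A few compounds are considered here, and "the series" means these few. Any claim that something is new, unique, unknown or untested is made for them only; others in the source may bear on it.

Measured compounds in a functional assay on THP-1 cells (Homo sapiens) for cytotoxicity, read by MTT assay, with a stated time of 24 h; on this read-out lower numbers stand for stronger inhibition and higher numbers for weaker inhibition:
Compound 1 `Cc1cc2ccccc2nc1-c1cn(CCC(F)(F)C(F)(F)C(F)(F)C(F)(F)C(F)(F)C(F)(F)C(F)(F)C(F)(F)F)nn1` gives > 100 ug/mL, a limit of the assay.
Compound 2 `CCCCCc1cc2ccccc2nc1-c1cn(-c2ccc(F)cc2)nn1` gives > 100 ug/mL, a limit of the assay.
Compound 3 `CCc1cc2ccccc2nc1-c1cn(-c2ccc(F)cc2)nn1` gives > 100 ug/mL, a limit of the assay.

Compound 1 stands at the limit of this assay (the limit of > 100 ug/mL in this assay, at which 3 of the 3 values shown sit), as do both other compounds shown; no number is available for it. Compound 4 `CCCc1cc2ccccc2nc1-c1cn(CCC(F)(F)C(F)(F)C(F)(F)C(F)(F)C(F)(F)C(F)(F)C(F)(F)C(F)(F)F)nn1` differs from compound 1 by ethyl in place of hydrogen on a saturated chain carbon bound to an aromatic carbon. Going by the values given here, the only measured single-point change, a step that the two limits leave unreadable from compound 2 to compound 3, is also a change of a chain on the shared core, but both of its ends are limits, so its size cannot be read. Among the compounds with values here, no measured step therefore gives a readable size for the change from compound 1 to compound 4 in this assay, and no step beyond the scatter is expected in either direction. Compound 4 is expected to sit at the limit as well, with a step that the limit leaves unreadable from compound 1 to compound 4 meaning essentially no change. The estimate for compound 4 is 200 ug/mL with an expected range from 80 ug/mL to 600 ug/mL.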

Compound 4, half-maximal inhibitory concentration: > 100 ug/mL
Compound 4: only a limit was reported (the forecaster's own chance of this, stated with the estimate: 85%); the middle value is on the limit's open side.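

In this assay, going by these compounds alone, compound 1 and compound 4 both stand at a limit, so no step between them can be read: the limit of > 100 ug/mL in this assay, at which 4 of the 4 values shown sit.

The compounds shown leave open whether any chain on the shared core changes cytotoxicity in this assay at all, and none of them gives a number.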